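Two hydrazide cores and one shared halogen swap

This account rests on a few compounds, and the source may have more. Where it says the series, first, only, none or still open, it means among the compounds named here.

Compound 1 `O=C(NNC(=O)c1cccc(Cl)c1)c1ccc(NS(=O)(=O)c2cnc(O)nc2O)cc1` and compound 3 `O=C(NNC(=O)c1cccc(NS(=O)(=O)c2cnc(O)nc2O)c1)c1cccc(Cl)c1` are built from the same atoms joined differently, and the difference between the two cores is not broken down here. In a functional assay on OVCAR-3 cells (Homo sapiens) for antiproliferative activity, read by MTT assay, with a stated time of 24 h (a higher number here means a weaker inhibitor, a lower number a stronger inhibitor), compound 1 gives 7710 nM, while compound 3 gives 13500 nM, and the two numbers sit within the usual scatter of each other. Compound 2 `O=C(NNC(=O)c1ccccc1F)c1ccc(NS(=O)(=O)c2cnc(O)nc2O)cc1` carries the change 2-fluorophenyl in place of 3-chlorophenyl on a carbonyl carbon on the core of compound 1, and in this assay compound 2 gives 16000 nM, which amounts to a 2.1-fold higher number from compound 1 to compound 2 (0.32 log units; beyond the scatter). Compound 4 `O=C(NNC(=O)c1ccccc1F)c1cccc(NS(=O)(=O)c2cnc(O)nc2O)c1` carries the same change, (2-fluorophenyl in place of 3-chlorophenyl on a carbonyl carbon), on the core of compound 3, at a place described in the same words as for compound 2. Because the measured step was a 2.1-fold higher number from compound 1 to compound 2 (0.32 log units; beyond the scatter), a step of similar size, a 2.1-fold higher number from compound 3 to compound 4 (0.32 log units; beyond the scatter), is expected here. That expectation rests on a single measured pair, so it is held loosely. Compound 4 is therefore expected to give about 28000 nM in this assay, with a likely range from 14000 nM to 60000 nM.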

Compound 4, half-maximal inhibitory concentration: 10800 nM
Compound 4: middle estimate off by 2.6-fold (0.41 log units), on the high side; measured number outside the range, below it.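

In this assay, within the data shown here, putting 2-fluorophenyl in place of 3-chlorophenyl on the core of compound 3 gives a 1.3-fold lower number from compound 3 to compound 4 (0.10 log units; within the scatter), so on this core the change leaves no step that can be told from the usual scatter. Set beside a 2.1-fold higher number from compound 1 to compound 2 (0.32 log units; beyond the scatter) on the core of compound 1, this step does not show that the two cores respond differently to the change: the same change on two cores in this assay, a 2.1-fold higher number (0.32 log units; beyond the scatter) from compound 1 to compound 2 and a 1.3-fold lower number (0.10 log units; within the scatter) from compound 3 to compound 4, 2.6-fold (0.41 log units) apart, within the scatter of two such steps Nor does it show that the change carries over faithfully from one core to the other, since only two pairs in a single assay stand behind the comparison, and a real difference of this size between the cores could not be told from scatter.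

The compounds shown leave open how either core responds when something other than a halogenated phenyl sits on that carbonyl carbon, such as a simple alkyl chain, or a phenyl ring bearing an amine or a carboxylic acid. They also leave open whether any such group would move the numbers on the two cores in step, by a margin clear of the scatter.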